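The source may report more compounds than this note shows. Statements on the series, on what has been measured and on what is new or still open speak of the compounds shown alone.

Compound 1 `C=C1[C@@H](OC(C)=O)C[C@@H]2[C@](C)(COC=O)[C@H](OC(C)=O)CC[C@@]2(C)[C@@H]1C[C@@H](Nc1ccc(OC)c(OC)c1)C1=CCOC1=O`: > 50000 nM
Compound 2 `C=C1[C@@H](OC(C)=O)C[C@@H]2[C@](C)(COC=O)[C@H](OC(C)=O)CC[C@@]2(C)[C@@H]1C[C@@H](Nc1ccc(OC)cc1)C1=CCOC1=O`: 32700 nM

Both compounds were tested in a functional assay on KB cells (Homo sapiens) for cytotoxicity, read by sulforhodamine B assay; a higher number here means a weaker inhibitor, a lower number a stronger inhibitor. Compound 1 reads > 50000 nM, which is a limit of the assay and not a number. Among the measured compounds shown here, compound 2 gives 32700 nM, the only true number so far, so it can be ranked against no other exact value.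

Compound 3 `C=C1[C@@H](OC(C)=O)C[C@@H]2[C@](C)(COC=O)[C@H](OC(C)=O)CC[C@@]2(C)[C@@H]1C[C@@H](Nc1ccc(C(=O)O)cc1)C1=CCOC1=O` keeps the shared core of compound 2 and has carboxy in place of methoxy on an aromatic carbon, para to a large group: carboxy in place of methoxy on an aromatic carbon.

For the measured compounds named here, only one measured step is available as a guide: an at least 1.5-fold lower number from compound 1 to compound 2 (0.18 log units; that floor lies within the scatter). There, hydrogen replaces methoxy on an aromatic carbon, so it touches a methoxy on the same ring but brings in no carboxy. It is therefore a loose guide. Going by the values given here, no measured compound carries carboxy, so no step beyond the scatter is expected in this assay, and no firm direction can be claimed. The expected change is a 1.2-fold higher number from compound 2 to compound 3 (0.09 log units; within the scatter). The estimate for compound 3 is 40000 nM, with an expected range from 15000 nM to 100000 nM.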

Compound 3, half-maximal inhibitory concentration: > 50000 nM
Compound 3 was reported as a limit (the forecaster's own chance of this, stated with the estimate: 45%); middle value at least 1.2-fold (0.09 log units) from the limit.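

In this assay compound 3 gives > 50000 nM, which is a limit of the assay and not a number. Placing carboxy instead of methoxy on this aromatic carbon, para to a large group, gives an at least 1.5-fold higher number from compound 2 to compound 3 (0.18 log units; that floor lies within the scatter), so the new compound shows no gain in cytotoxicity over the 4-methoxyphenyl compound, and compound 2 still holds the only exact value. How large this step truly is remains unknown, and the step between the two limits, compound 1 and compound 3, cannot be read, because the readings stop at the same point: the limit of > 50000 nM in this assay, at which 2 of the 3 values shown sit.

The compounds shown leave open whether a methyl ester, an amide or an amine on this same aromatic carbon would give a reading inside the range of the assay, and so a step that could be sized. They also leave open whether a chlorine atom or a longer alkoxy chain here would give a number clearly apart from that of compound 2, which would show whether this position matters at all.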